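Removing the aromatic-oxygen substituent entirely: compound 4

The compounds below may be only part of what the source reports. "The series", "measured", "known", "first", "only" and "open" are said of these compounds alone.

Among the compounds with values here, the series so far holds three compounds that differ only in the group on the aromatic oxygen of the shared core. Compound 1 `CCCOc1ccc2oc(/C=C/[S+](C)[O-])cc(=O)c2c1` gives 6200 nM in a functional assay on DLD-1 cells (Homo sapiens) for cytotoxicity, with a stated time of 48 h; a lower number here means a stronger inhibitor, a higher number a weaker inhibitor. Compound 2 `CCOc1ccc2oc(/C=C/[S+](C)[O-])cc(=O)c2c1` gives 4900 nM in this assay. Compound 3 `CC(C)C(=O)Oc1ccc2oc(/C=C/[S+](C)[O-])cc(=O)c2c1` gives 9100 nM in this assay. Compound 3 stands highest of the three numbers, but its nearest neighbour is compound 1 and its furthest is compound 2, and both gaps are within the scatter, so no order among the three can be read from these values.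

Compound 4 `C[S+]([O-])/C=C/c1cc(=O)c2ccccc2o1` has not yet been measured. It differs from compound 3 as follows: hydrogen in place of (isopropylcarbonyl)oxy on an aromatic carbon. All three measured steps vary the group on the aromatic oxygen while keeping that oxygen in place: a 1.3-fold lower number from compound 1 to compound 2 (0.10 log units; within the scatter), a 1.5-fold higher number from compound 1 to compound 3 (0.17 log units; within the scatter) and a 1.9-fold higher number from compound 2 to compound 3 (0.27 log units; within the scatter). None of them removes the oxygen together with its group, so none bears directly on this change; what they do show is that the numbers in this assay have been indifferent to what sits on that oxygen. The expectation for compound 4 is therefore a step of a 1.3-fold lower number from compound 3 to compound 4 (0.11 log units; within the scatter), expected to stay within the scatter, with the direction undetermined. Compound 4 is estimated to give 7000 nM in this assay, within an expected range from 2500 nM to 20000 nM.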

Compound 4, half-maximal inhibitory concentration: 8000 nM
For compound 4 the middle estimate is 1.1-fold (0.06 log units) below the measured one; the measured number falls inside the stated range.
By their numbers in this assay, from the lowest: compounds 2, 1, 4 and 3 (each within the scatter of the next).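

Within the data shown here, removing the whole substituent together with its oxygen, which the earlier steps left in place, stays within the scatter in this assay whichever group leaves: (isopropylcarbonyl)oxy (a 1.1-fold lower number from compound 3 to compound 4 (0.06 log units; within the scatter)), ethoxy (a 1.6-fold higher number from compound 2 to compound 4 (0.21 log units; within the scatter)) or propoxy (a 1.3-fold higher number from compound 1 to compound 4 (0.11 log units; within the scatter)). This aromatic carbon can therefore carry hydrogen alone with no readable difference from the three oxygen-linked groups, so the oxygen is not needed for the numbers seen in this series, and the four compounds cannot be ranked. Nothing available explains why the numbers stay together at this position.

Whether any group on this carbon can move the number beyond the scatter remains open, since an amine, a carboxylic acid and a longer chain such as octyloxy are not among the compounds shown. The rest of the shared core is the same in all four compounds, so these numbers also leave open which other part of the structure, if any, the number in this assay responds to.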